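The compounds below may be only part of what the source reports. "The series", "measured", "known", "first", "only" and "open" are said of these compounds alone.

Of the compounds shown here, three sharing one core have been measured in a functional assay on MKN-45 cells (Homo sapiens) for cytotoxicity; on this read-out lower numbers stand for stronger inhibition and higher numbers for weaker inhibition. Compound 1 `COc1ccc(S(=O)(=O)N2CCc3cccc(NC(=O)C(C)(C)C)c32)cc1`, with tert-butyl on the carbonyl carbon, gives 289 nM. Compound 2 `COc1ccc(S(=O)(=O)N2CCc3cccc(NS(=O)(=O)c4ccc(F)cc4)c32)cc1`, with (4-fluorophenyl)sulfonyl in place of (tert-butyl)carbonyl on a nitrogen on an aromatic ring, gives 890 nM. Compound 3 `COc1ccc(S(=O)(=O)N2CCc3cccc(NC(=O)c4cccs4)c32)cc1`, with thiophen-2-yl on the carbonyl carbon, gives 31 nM, the lowest of the three numbers.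

Compound 4 `COC(=O)c1ccc(C(=O)Nc2cccc3c2N(S(=O)(=O)c2ccc(OC)cc2)CC3)cc1` has not yet been measured. It has 4-(methoxycarbonyl)phenyl in place of thiophen-2-yl on a carbonyl carbon. Going by the values given here, only one measured step changes the group at that carbon: a 9.3-fold lower number from compound 1 to compound 3 (0.97 log units; beyond the scatter), a modest step. The steps of a 3.1-fold higher number from compound 1 to compound 2 (0.49 log units; beyond the scatter), also modest, and a 29-fold lower number from compound 2 to compound 3 (1.46 log units; beyond the scatter), a large one, show how far the numbers move when the group on the nitrogen is exchanged. Among the compounds with values here, no measured compound carries the entering group, so the expectation rests on the modest step of a 9.3-fold lower number from compound 1 to compound 3 (0.97 log units; beyond the scatter) read in reverse, towards a higher number in this assay. The expected change is a 3.2-fold higher number from compound 3 to compound 4 (0.51 log units; beyond the scatter). The estimate for compound 4 is 100 nM, with an expected range from 25 nM to 400 nM.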

Compound 4, half-maximal inhibitory concentration: 312 nM
The estimate for compound 4 lay 3.1-fold (0.49 log units) below the measured number, within the range that was stated.
By their numbers in this assay, from the lowest: compound 3; then compounds 1 and 4 (each within the scatter of the next); then compound 2.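

With thiophen-2-yl replaced by 4-(methoxycarbonyl)phenyl on the carbonyl carbon, this assay shows a 10-fold higher number from compound 3 to compound 4 (1.00 log units; beyond the scatter) and thus that an aromatic ring at this place does not by itself keep the low number of compound 3. Exchanging tert-butyl for the same group gives a 1.1-fold higher number from compound 1 to compound 4 (0.03 log units; within the scatter) and leaves compound 1 and compound 4 indistinguishable, although one group is a six-membered aromatic ring with a methoxycarbonyl group and the other has no ring. Of the three groups compared at this carbon, only thiophen-2-yl stands apart from the other two.

The compounds shown leave open what furan-2-yl, plain phenyl or 4-carboxyphenyl would give at this carbon. Nothing given here explains why thiophen-2-yl stands apart.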